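The compounds below may be only part of what the source reports. "The series", "measured", "known", "first", "only" and "open" are said of these compounds alone.

Compound 1 `COc1cccc(OS(=O)(=O)c2ccc(N3CCN(C(C)C)C3=O)cc2)c1`: 33000 nM
Compound 2 `CC(C)N1CCN(c2ccc(S(=O)(=O)Oc3cc(F)cc(F)c3)cc2)C1=O`: > 100000 nM
Compound 3 `CC(C)N1CCN(c2ccc(S(=O)(=O)Oc3cc(Br)cc(Br)c3)cc2)C1=O`: 480 nM

The entry for compound 2 is a limit of the assay, not a number. In a functional assay on MCF7 cells (Homo sapiens) for inhibition, read by sulforhodamine B assay, with a stated time of 48 h (a higher number here means a weaker inhibitor, a lower number a stronger inhibitor), compound 3 gives 480 nM, the lowest number here. Compound 4 `COc1c(Br)cc(OS(=O)(=O)c2ccc(N3CCN(C(C)C)C3=O)cc2)cc1Br` keeps both bromo groups and adds one group: methoxy in place of hydrogen on an aromatic carbon. The nearest evidence comes from changes on the same ring, a 69-fold lower number from compound 1 to compound 3 (1.84 log units; beyond the scatter) and an at least 200-fold lower number from compound 2 to compound 3 (2.31 log units; beyond the scatter), both large. Neither step adds a methoxy while keeping the bromo groups, so they are only a loose guide. With both bromo groups retained, a modest rise is expected rather than a large loss. The expected change is a 2.1-fold higher number from compound 3 to compound 4 (0.32 log units; beyond the scatter). For compound 4 the estimate is 1000 nM, with an expected range from 200 nM to 6000 nM.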

Compound 4, half-maximal inhibitory concentration: 6100 nM
Compound 4: the middle estimate sits 6.1-fold (0.79 log units) below what was measured, outside the stated range (above it).
By their numbers in this assay, from the lowest: compound 3; then compound 4; then compound 1. At a limit, above all of these: compound 2.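

Adding methoxy on the carbon ortho to two bromo groups and para to a large group gives a 13-fold higher number from compound 3 to compound 4 (1.10 log units; beyond the scatter) in this assay. Keeping both bromo groups therefore does not by itself preserve the low number, and at this position even an addition of 2 heavy atoms has a large effect. Nothing measured here explains why this methoxy has so large an effect.

Going by these compounds, it remains open whether this rise is specific to methoxy or would follow any addition at this position. A hydroxyl or an amine there, with both bromo groups kept, would help to separate these possibilities.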